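This account rests on a few compounds, and the source may have more. Where it says the series, first, only, none or still open, it means among the compounds named here.

Working notes on the series. All three measured compounds share the core of compound 1 `Nc1nc(N/N=C/c2ccc3ncccc3c2)nc2c1ncn2[C@@H]1O[C@H](CO)[C@@H](O)[C@H]1O` and are compared in an assay on CHO-K1 cells for displacement of a labelled ligand from adenosine receptor A1 (Homo sapiens), read by scintillation counting, with a stated time of 60 min; a lower number here means a stronger inhibitor, a higher number a weaker inhibitor. In this assay compound 1 gives 9.8 nM, the lowest of the two numbers recorded. Compound 3 `Nc1nc(N/N=C/c2ccc(-c3ccccc3)cc2)nc2c1ncn2[C@@H]1O[C@H](CO)[C@@H](O)[C@H]1O` gives 7860 nM in this assay, a gap from compound 1 that lies well beyond the scatter. For compound 2 `Nc1nc(N/N=C/c2ccc(N(c3ccccc3)c3ccccc3)cc2)nc2c1ncn2[C@@H]1O[C@H](CO)[C@@H](O)[C@H]1O` this assay reports only a limit, > 10000 nM, and not a number. That reading is the limit of > 10000 nM in this assay, at which 1 of the 3 values shown sits.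

Going by the values given here, no pair among the measured compounds differs in one place, so no measured step is available. Compound 4 `CSCC/C=N/Nc1nc(N)c2ncn([C@@H]3O[C@H](CO)[C@@H](O)[C@H]3O)c2n1` is not yet measured. Relative to compound 1 the change is 2-(methylsulfanyl)ethyl in place of quinolin-6-yl on a carbon with a double bond to nitrogen. Both other measured variations at the same carbon, compound 2 and compound 3, gave far weaker results than compound 1, though they carry ring systems and compound 4 carries none, so the size of the step is uncertain. A loss beyond the scatter is expected, but a smaller one than those seen for compound 2 and compound 3.

In this assay compound 4 is expected to give 300 nM, in the range 40 nM to 3000 nM. The expected step is a 31-fold higher number from compound 1 to compound 4 (1.49 log units; beyond the scatter).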

Compound 4, inhibition constant: > 10000 nM
Compound 4 was reported as a limit; the forecaster's own chance of this, stated with the estimate: 10%; middle value at least 33-fold (1.52 log units) away from the limit.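

The step of an at least 1000-fold higher number from compound 1 to compound 4 (3.00 log units; beyond the scatter) in this assay, for 2-(methylsulfanyl)ethyl in place of quinolin-6-yl on a carbon with a double bond to nitrogen, shows that the loss at this carbon is not confined to groups carrying ring systems, as in compound 2 and compound 3, since a group with no ring loses as well. Among the four compounds shown, quinolin-6-yl in compound 1 remains the only group with a low reading, so neither the ring-bearing groups nor the open chain replace it at this carbon. The reading for compound 4 is a limit and not a number, and compound 2 rests at the same limit, so these two cannot be ordered against each other: the limit of > 10000 nM in this assay, at which 2 of the 4 values shown sit.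

From the compounds shown here alone, what remains open is whether the ring nitrogen of quinolin-6-yl matters, which naphthalen-2-yl at the same carbon would test, and whether a single ring such as pyridin-3-yl keeps any of the reading of compound 1. Going by these compounds, it is also open whether an open chain ending in an amine or a carboxylic acid would behave differently from 2-(methylsulfanyl)ethyl.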